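Swapping the benzothiazole substituent on a triazole amine

The source may report more compounds than this note shows. Statements on the series, on what has been measured and on what is new or still open speak of the compounds shown alone.

Compound 2 `O=[N+]([O-])c1ccc(-c2nnc(-c3cccnc3)n2Nc2nc3ccc(Br)cc3s2)cc1` was examined in an ADME assay on MT4 cells (Homo sapiens) for cytotoxicity, read by MTT assay, with a stated time of 5 days (on this read-out lower numbers stand for higher toxicity in this test and higher numbers for lower toxicity in this test), where compound 2 gave 13.2 ug/mL. Among the three measured compounds this is the second highest number. Compound 1 `NNc1nc2ccc(Br)cc2s1`, which gave 8.01 ug/mL, lies nearest to it, and that gap is within the scatter. Compound 3 `O=[N+]([O-])c1ccc(-c2nnc(-c3cccnc3)n2Nc2nc3ccc([N+](=O)[O-])cc3s2)cc1` gave 50.8 ug/mL and lies furthest away: the step of a 3.8-fold higher number from compound 2 to compound 3 (0.59 log units; beyond the scatter) is the only one measured, and it puts nitro in place of bromo on the ring attached to the amine nitrogen.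

Compound 4 `O=[N+]([O-])c1ccc(-c2nnc(-c3cccnc3)n2Nc2nc3c(Cl)cccc3s2)cc1` has not been measured. It differs from compound 2 by 4-chloro-1,3-benzothiazol-2-yl in place of 6-bromo-1,3-benzothiazol-2-yl on a nitrogen on an aromatic ring. For the measured compounds named here, no measured step exchanges one halogen for another or moves a substituent around that ring; the single step that does touch this ring, from compound 2 to compound 3, introduces nitro instead, so it gives only a loose guide. Going by the values given here, because the only comparable change, a 3.8-fold higher number from compound 2 to compound 3 (0.59 log units; beyond the scatter), was modest and of a different kind, the step from compound 2 to compound 4 is expected to be small, most likely within the scatter, in either direction. The expectation for compound 4 in this assay is therefore 15 ug/mL, with a plausible range from 6 ug/mL to 40 ug/mL, corresponding to an estimated step of a 1.1-fold higher number from compound 2 to compound 4 (0.06 log units; within the scatter).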

Compound 4, half-maximal cytotoxic concentration: 15.6 ug/mL
Beside the measured number, compound 4's estimate is 1.0-fold (0.02 log units) below it, within the range that was stated.
By their numbers in this assay, from the lowest: compounds 1, 2 and 4 (each within the scatter of the next); then compound 3.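

Taking 4-chloro-1,3-benzothiazol-2-yl in place of 6-bromo-1,3-benzothiazol-2-yl on the amine nitrogen gives a 1.2-fold higher number from compound 2 to compound 4 (0.07 log units; within the scatter) in this assay, so this exchange, in which the halogen and its place on the ring differ together, leaves the two compounds indistinguishable on this read-out. For the compounds shown here, until now the only measured change on this ring was the nitro exchange, a 3.8-fold higher number from compound 2 to compound 3 (0.59 log units; beyond the scatter), and the new pair shows that not every change of substituent on this ring goes beyond the scatter, although two compounds cannot establish a rule. Nothing measured here explains either step.

Because the halogen and its place differ at the same time, the compounds shown cannot say whether each alone would leave the number unchanged or whether two separate effects happen to offset each other. Going by these compounds, it also remains open whether an amine or a methoxy group on this ring would stay with the halogen compounds 2 and 4 or go with the nitro compound 3, and how the ring with no substituent at all would compare.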